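Second chloro on the urea-linked phenyl ring

The source may hold more compounds than are shown below. What is called first, only, known or untested is meant among the compounds shown, and "the series" means these compounds.

Compounds measured so far:
compound 1 `Cc1cc(NC(=O)Nc2ccc(C)c(Cl)c2)c2ccccc2n1` gives 300 nM
compound 2 `Cc1ccc(NC(=O)Nc2cc(C)nc3ccccc23)cc1` gives 1300 nM
compound 3 `Cc1cc(NC(=O)Nc2ccc(Cl)cc2)c2ccccc2n1` gives 1400 nM

These values come from a physicochemical assay for solubility, at pH 7.4; a higher number here means a more soluble compound, a lower number a less soluble compound. Compound 4 `Cc1cc(NC(=O)Nc2ccc(Cl)cc2Cl)c2ccccc2n1` has not yet been measured there. It arises from compound 3 by chloro in place of hydrogen on an aromatic carbon. The same kind of change links compound 2 to compound 1, by chloro in place of hydrogen on an aromatic carbon, and in this assay it made a 4.3-fold lower number from compound 2 to compound 1 (0.64 log units; beyond the scatter). The surroundings differ, though: in compound 1 the new chloro sits ortho to a methyl group and meta to a large group, whereas in compound 4 it sits ortho to a large group and meta to a chloro group. The two cores differ by chloro in place of methyl on an aromatic carbon, a change that made a 1.1-fold higher number from compound 2 to compound 3 (0.03 log units; within the scatter). Resting on the step from compound 2 to compound 1, compound 4 is expected to show a 4.0-fold lower number from compound 3 to compound 4 (0.60 log units; beyond the scatter), so the estimate for compound 4 is 350 nM, between 120 nM and 900 nM.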

Compound 4, solubility: 100 nM
For compound 4 the middle estimate is 3.5-fold (0.54 log units) above the measured one; the whole stated range lies above it.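

In this assay, adding a chloro gives a 14-fold lower number from compound 3 to compound 4 (1.15 log units; beyond the scatter), and the same kind of change gives a 4.3-fold lower number from compound 2 to compound 1 (0.64 log units; beyond the scatter). Across these two pairs the direction of the step carries from one core to the other but its size does not, and two pairs cannot show that this would hold for other cores. The new chloro differs in both its surroundings and its core between the pairs, and no measurement shown explains the difference in size.

On these data alone, it remains open whether a chloro ortho to a large group would give a similar step on the core of compound 2. As far as these compounds go, it also remains open how an amine or a carboxylic acid in that same place would compare with chloro.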